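Swapping a nitro-bearing ring for a plain phenol

The compounds below may be only part of what the source reports. "The series", "measured", "known", "first", "only" and "open" are said of these compounds alone.

Measured compounds and their values:
- compound 1, `Cn1c(=O)c(S(=O)(=O)c2ccc(F)cc2F)cc2cnc(Nc3ccc4cc[nH]c4c3)nc21`: 5000 nM
- compound 2, `Cn1c(=O)c(S(=O)(=O)c2ccc(F)cc2[N+](=O)[O-])cc2cnc(Nc3ccc4[nH]ccc4c3)nc21`: 900 nM
- compound 3, `Cn1c(=O)c(S(=O)(=O)c2ccc([N+](=O)[O-])cc2F)cc2cnc(Nc3ccc4[nH]ccc4c3)nc21`: 200 nM

All three were tested in a functional assay on K562 cells (Homo sapiens) for inhibition, read by trypan blue exclusion, with a stated time of 72 h; on this read-out higher numbers stand for weaker inhibition and lower numbers for stronger inhibition. Compound 3 has the lowest number of the three; compound 2 sits nearest to it, and compound 1 is furthest away. Compound 1 and compound 3 differ in more than one place, so their two values are only compared as they stand. Compound 4, `Cn1c(=O)c(S(=O)(=O)c2ccc(O)cc2)cc2cnc(Nc3ccc4[nH]ccc4c3)nc21`, has not yet been measured; it differs from compound 3 in one place: 4-hydroxyphenyl in place of 2-fluoro-4-nitrophenyl on a sulfonyl sulfur.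

For the measured compounds named here, only one measured step bears on this change, the one on the same sulfonyl sulfur: a 4.5-fold lower number from compound 2 to compound 3 (0.65 log units; beyond the scatter). That step shows that the pattern of substituents on this ring can move the number well beyond the scatter, even when the same two groups are merely rearranged. Compound 4 removes both of those groups and puts in a hydroxyl instead, a larger departure than the one measured. A step in the weakening direction is therefore expected, modest in size, though with wide uncertainty, the expected step being a 4.0-fold higher number from compound 3 to compound 4 (0.60 log units; beyond the scatter). The estimate for compound 4 in this assay is 800 nM, within a range from 200 nM to 3000 nM.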

Compound 4, half-maximal inhibitory concentration: 100 nM
Compound 4: middle estimate off by 8.0-fold (0.90 log units), on the high side; the measured number lies below the stated range.
By their numbers in this assay, from the lowest: compounds 4 and 3 (each within the scatter of the next); then compound 2; then compound 1.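

In this assay, the replacement of the 2-fluoro-4-nitrophenyl ring by 4-hydroxyphenyl on this sulfonyl sulfur gives (a 2.0-fold lower number from compound 3 to compound 4 (0.30 log units; within the scatter)), so these two compounds cannot be told apart, and compound 4 shows that a number of this size does not require the nitro group or the fluorine on this ring. Starting from the rearranged ring of compound 2, the same kind of replacement gives (a 9.0-fold lower number from compound 2 to compound 4 (0.95 log units; beyond the scatter)), so the apparent effect of introducing 4-hydroxyphenyl depends on which ring it replaces: the step lies beyond the scatter from one and within it from the other. Nothing here explains why two such different rings give values within the scatter of each other.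

Going by these compounds, the role of the hydroxyl itself remains open, and an unsubstituted phenyl, 4-methoxyphenyl or 4-aminophenyl ring on the same sulfonyl sulfur would give the direct comparison. Also open, on these data alone, is how the fluorinated ring of compound 1 would read on the core of compound 4, as compound 1 differs from the others in more than one place.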